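Swapping a side group for cyano on the shared core

The source may report more compounds than this note shows. Statements on the series, on what has been measured and on what is new or still open speak of the compounds shown alone.

- Compound 1 `CC/N=C(\S)[C@]1(c2cccnc2)CCCC[S+]1[O-]`: 300 nM
- Compound 2 `[O-][S+]1CCCC[C@]1(/C(S)=N/c1ccccc1)c1cccnc1`: > 30000 nM (a limit)
- Compound 3 `COC(=O)CC/N=C(\S)[C@]1(c2cccnc2)CCCC[S+]1[O-]`: > 30000 nM (a limit)

Among the compounds with values here, in a functional assay (aorta) for inhibition, with Rattus norvegicus as the target (a higher number here means a weaker inhibitor, a lower number a stronger inhibitor), compound 1 gives 300 nM, the only true number among the three results. The result for compound 2 is a limit. The result for compound 3 is also a limit.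

Compound 4 `N#C[C@]1(c2cccnc2)CCCC[S+]1[O-]` has not yet been measured. It differs from compound 1 on a saturated ring carbon: a group of 2 heavy atoms (1 carbon, 1 nitrogen; no ring) in place of a group of 5 heavy atoms (3 carbon, 1 nitrogen, 1 sulfur; no ring), on a saturated ring carbon. Cyano enters there, in place of the larger group that holds the double-bonded nitrogen.

Two measured steps changed that same group of compound 1 without removing it: an at least 100-fold higher number from compound 1 to compound 2 (2.00 log units; beyond the scatter) and an at least 100-fold higher number from compound 1 to compound 3 (2.00 log units; beyond the scatter). Both are large and beyond the scatter. Within the data shown here, with these two steps as the only guide, a large rise in the number, meaning a weaker inhibitor, is expected for compound 4 too. The expected change is a 67-fold higher number from compound 1 to compound 4 (1.82 log units; beyond the scatter). For compound 4 the estimate is 20000 nM, with an expected range of 3000 nM to 100000 nM.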

Compound 4, concentration for 90% inhibition: > 30000 nM
Compound 4: a limit, no number (the forecaster's own chance of this, stated with the estimate: 60%); middle value at least 1.5-fold (0.17 log units) from the limit.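

In this assay, cyano in place of the larger group that holds the double-bonded nitrogen gives an at least 100-fold higher number from compound 1 to compound 4 (2.00 log units; beyond the scatter). The earlier changes altered only the far end of that group, whereas this one replaces the whole group, including its hydrogen-bond donor, and the result is again a limit rather than a number. Of the groups shown on this saturated ring carbon, only the one in compound 1 gives a true number, and no step or order among compound 2, compound 3 and compound 4 can be read: the limit of > 30000 nM in this assay, at which 3 of the 4 values shown sit.

Going by these compounds, it remains open whether a smaller or longer chain on the double-bonded nitrogen, such as methyl or propyl, would keep a measurable number. On these data alone, it is also open whether a simple amide on the ring carbon, with oxygen in place of the sulfur of compound 1, would do the same.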